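A few compounds are considered here, and "the series" means these few. Any claim that something is new, unique, unknown or untested is made for them only; others in the source may bear on it.

Of the compounds shown here, three built on one shared core have been measured in an ADME assay on THP-1 cells (Homo sapiens) for cytotoxicity, read by flow cytometry and propidium iodide staining, with a stated time of 72 h; a lower number here means a stronger inhibitor, a higher number a weaker inhibitor. Compound 1 `Cc1nc(CS(=O)(=O)c2ccccc2)c([N+](=O)[O-])n1CCO` gives only a limit of > 768000 nM in this assay, not a number (the limit of > 768000 nM in this assay, at which 1 of the 3 values shown sits). Compound 2 `Cc1ccc(S(=O)(=O)Cc2nc(C)n(CCO)c2[N+](=O)[O-])cc1` gives 59000 nM, and compound 3 `Cc1nc(CS(=O)(=O)c2ccc(Br)cc2)c([N+](=O)[O-])n1CCO` gives 124000 nM, so compound 2 stands lowest of the two numbers, with a 2.1-fold higher number from compound 2 to compound 3 (0.32 log units; beyond the scatter). The measured steps, an at least 13-fold lower number from compound 1 to compound 2 (1.11 log units; beyond the scatter) and an at least 6.1-fold lower number from compound 1 to compound 3 (0.79 log units; beyond the scatter), each change a group on the aromatic ring. Compound 4 `Cc1ccc(S(=O)(=O)Cc2nc(C)n(CC(C)O)c2[N+](=O)[O-])cc1` differs from compound 2 elsewhere: methyl in place of hydrogen on a saturated chain carbon bound to an oxygen on a saturated carbon and a saturated chain carbon. Among the measured compounds shown here, no measured step touches that chain, so the earlier steps offer no guidance here, and a step within the usual scatter is expected. Compound 4 is therefore expected to give about 59000 nM in this assay, within 25000 nM to 140000 nM, meaning no change at the digits printed from compound 2 to compound 4 (within the scatter).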

Compound 4, half-maximal inhibitory concentration: > 707000 nM
Compound 4 was reported as a limit; the forecaster's own chance of this, stated with the estimate: 5%; middle value at least 11-fold (1.07 log units) from the limit.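

The side chain matters as well as the aromatic ring: changing 2-hydroxyethyl to 2-hydroxypropyl, a single added methyl, gives an at least 11-fold higher number from compound 2 to compound 4 (1.07 log units; beyond the scatter). Compound 4 gives only a limit, not a number: the limit of > 707000 nM in this assay, at which 1 of the 4 values shown sits.

As far as these compounds go, this step is therefore a minimum, and its true size remains unknown. From the compounds shown here alone, it remains open whether a longer chain, such as 3-hydroxypropyl, or an amine in place of the hydroxyl would behave more like compound 2 or compound 4. The same methyl might also act differently on compound 3, which carries bromo on the aromatic ring.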